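A few compounds are considered here, and "the series" means these few. Any claim that something is new, unique, unknown or untested is made for them only; others in the source may bear on it.

Measured so far in an assay on Huh-7 cells for agonist activity at Bile acid receptor (Homo sapiens), read by a luciferase reporter; a lower number here means that less compound is needed, a higher number that more compound is needed for the effect: compound 1 `CCC(CC)n1c(-c2ccc(OCc3c(-c4c(Cl)cccc4Cl)noc3C(C)C)cc2)nc2ccc(C(=O)O)cc21` gives 0.8 nM; compound 2 `CCCC(CCC)n1c(-c2ccc(OCc3c(-c4c(Cl)cccc4Cl)noc3C(C)C)cc2)nc2ccc(C(=O)O)cc21` gives 1.8 nM. Among the measured compounds shown here, compound 2 holds the higher of the two numbers, with a 2.3-fold higher number from compound 1 to compound 2 (0.35 log units; beyond the scatter) the only step available. Compound 3 `CC(C)c1onc(-c2c(Cl)cccc2Cl)c1COc1ccc(-c2nc3ccc(C(=O)O)cc3n2C2CCCCCC2)cc1` changes compound 2 by cycloheptyl in place of 1-propylbutyl on an aromatic nitrogen. For the measured compounds named here, the one measured step, pentan-3-yl to 1-propylbutyl, concerned chain length and was modest; no step on ring closure at this position exists here, so compound 3 is expected to stay near compound 2, with a 1.2-fold lower number from compound 2 to compound 3 (0.08 log units; within the scatter) inside the scatter. The estimate for compound 3 in this assay is 1.5 nM, range 0.5 nM to 4.5 nM.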

Compound 3, half-maximal effective concentration: 14.8 nM
Compound 3: the middle estimate sits 9.9-fold (0.99 log units) below what was measured, outside the stated range (above it).
By their numbers in this assay, from the lowest: compound 1; then compound 2; then compound 3.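

In this assay, the substituent on the aromatic nitrogen responds to more than its carbon count: cycloheptyl and 1-propylbutyl have the same count of heavy atoms, yet the ring gives an 8.2-fold higher number from compound 2 to compound 3 (0.91 log units; beyond the scatter). Against the shorter open-chain pentan-3-yl, the change reaches a 19-fold higher number from compound 1 to compound 3 (1.27 log units; beyond the scatter), so among these three compounds, the ring gives the highest number. No available evidence accounts for this difference. Still open, on these data alone, is whether smaller rings such as cyclopentyl or cyclohexyl behave like cycloheptyl or like the open chains.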